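This account rests on a few compounds, and the source may have more. Where it says the series, first, only, none or still open, it means among the compounds named here.

The measured compounds:
Compound 1, `CCNC(=O)Nc1cccc(S(=O)(=O)Oc2ccccc2C)c1`, gives 55000 nM in a functional assay on MCF7 cells (Homo sapiens) for cytotoxicity, read by sulforhodamine B assay, with a stated time of 48 h; on this read-out higher numbers stand for weaker inhibition and lower numbers for stronger inhibition.
Compound 2, `CCNC(=O)Nc1cccc(S(=O)(=O)Oc2ccccc2CC)c1`, gives 31000 nM in this assay.

Compound 2 holds the lower of the two numbers in this assay; its nearest neighbour is compound 1, and the step between them, a 1.8-fold lower number from compound 1 to compound 2 (0.25 log units; within the scatter), lies within the scatter, so the two cannot be placed in order. Compound 3, `CCNC(=O)Nc1cccc(S(=O)(=O)Oc2ccc(O)cc2)c1`, has not yet been measured. It differs from compound 2 by 4-hydroxyphenyl in place of 2-ethylphenyl on an oxygen. Among the compounds with values here, the only measured step concerns a methyl in place of hydrogen on a saturated chain carbon bound to an aromatic carbon, not the exchange of the whole 2-ethylphenyl group for a 4-hydroxyphenyl group, and that step was itself within the scatter. Within the data shown here, no measured step therefore bears directly on the change from compound 2 to compound 3. With nothing pointing one way, compound 3 is expected to show no step beyond the scatter in this assay, the expected step being a 1.5-fold higher number from compound 2 to compound 3 (0.16 log units; within the scatter). Compound 3 is accordingly estimated at 45000 nM, with a range from 15000 nM to 150000 nM.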

Compound 3, half-maximal inhibitory concentration: 64000 nM
Beside the measured number, compound 3's estimate is 1.4-fold (0.15 log units) below it; low and high end bracket the measured number.
By their numbers in this assay, from the lowest: compounds 2, 1 and 3 (each within the scatter of the next, the first and the last beyond it).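

In this assay, within the data shown here, the exchange on the oxygen whose other neighbour is the sulfonyl sulfur yields the first step beyond the scatter in this set: 4-hydroxyphenyl in place of 2-ethylphenyl gives a 2.1-fold higher number from compound 2 to compound 3 (0.31 log units; beyond the scatter), although this step is only modest. The same group in place of 2-methylphenyl gives a 1.2-fold higher number from compound 1 to compound 3 (0.07 log units; within the scatter), which lies within the scatter, so compound 1 and compound 3 cannot be placed in order, and the exchange separates compounds only when 2-ethylphenyl is the group that leaves. Nothing measured here gives a reason for this difference between the two exchanges.

The 2-ethylphenyl and 4-hydroxyphenyl groups differ in more than one respect, so these three compounds cannot show which part of the exchange goes with the step from compound 2 to compound 3. Groups such as 4-ethylphenyl, 2-hydroxyphenyl, 4-methoxyphenyl or unsubstituted phenyl on the same oxygen would be needed to separate those parts, and how an amine or a carboxylic acid on the aromatic ring would read in this assay also remains open.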